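Acetyl for Tert-Butyl on the Phenyl Ring

The source may report more compounds than this note shows. Statements on the series, on what has been measured and on what is new or still open speak of the compounds shown alone.

Of the compounds shown here, three built on one shared core have been tested in a functional assay on B16-F0 cells (Mus musculus) for inhibition, read by CCK-8 assay, with a stated time of 48 h; on this read-out higher numbers stand for weaker inhibition and lower numbers for stronger inhibition. Compound 1 `COc1ccc(-c2cc3nccc(-c4cc(OC)c(OC)c(OC)c4)n3n2)cc1N` gives 88 nM in this assay, and compound 2 `COc1cc(-c2ccnc3cc(-c4ccc5cc[nH]c5c4)nn23)cc(OC)c1OC` gives 55 nM, a difference of a 1.6-fold lower number from compound 1 to compound 2 (0.20 log units; within the scatter). Compound 3 `COc1cc(-c2ccnc3cc(-c4ccc(C(C)(C)C)cc4)nn23)cc(OC)c1OC` is recorded at > 10000 nM, which is a limit of the assay and not a number. Compound 3 therefore stands at the weak end of what has been measured, separated from the others by an at least 110-fold higher number from compound 1 to compound 3 (2.05 log units; beyond the scatter) and by an at least 180-fold higher number from compound 2 to compound 3 (2.25 log units; beyond the scatter).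

Compound 4 `COc1cc(-c2ccnc3cc(-c4ccc(C(C)=O)cc4)nn23)cc(OC)c1OC` has not been measured. It differs from compound 3 in one place: acetyl in place of tert-butyl on an aromatic carbon

Among the measured compounds shown here, no measured step changes exactly this group. The two large steps into compound 3 both replaced the 3-amino-4-methoxyphenyl or the 1H-indol-6-yl with 4-(tert-butyl)phenyl and both lost much; moving away from tert-butyl toward a group with one hydrogen-bond acceptor may recover part of that. Compound 4 is accordingly expected near 2000 nM, within 200 nM to 15000 nM. The expected step is an at least 5.0-fold lower number from compound 3 to compound 4 (0.69 log units; beyond the scatter), uncertain since it starts from a limit.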

Compound 4, half-maximal inhibitory concentration: 3930 nM
Beside the measured number, compound 4's estimate is 2.0-fold (0.29 log units) below it, and the stated range covers the measured number.
By their numbers in this assay, from the lowest: compounds 2 and 1 (each within the scatter of the next); then compound 4. At a limit, above all of these: compound 3.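

In this assay, acetyl in place of tert-butyl brings this position back into the measurable range, with an at least 2.5-fold lower number from compound 3 to compound 4 (0.40 log units; beyond the scatter). Compound 3 is recorded only at a limit, so that step gives a minimum size and not a true one: the limit of > 10000 nM in this assay, at which 1 of the 4 values shown sits. The recovery is only partial, as 4-acetylphenyl remains far weaker than the two groups that carry the strongest numbers here, with a 45-fold higher number from compound 1 to compound 4 (1.65 log units; beyond the scatter) and a 71-fold higher number from compound 2 to compound 4 (1.85 log units; beyond the scatter).

On these data alone, whether an amine, a hydroxyl group or a carboxylic acid in the same place on the phenyl ring would move the number closer to those of compound 1 and compound 2 remains open. Also open, as far as these compounds go, is whether the carbonyl itself matters, a question that a comparison with the matching alcohol or a longer chain such as propanoyl could help to answer.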